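A ring swap from compound 3 to compound 4

The source may hold more compounds than are shown below. What is called first, only, known or untested is meant among the compounds shown, and "the series" means these compounds.

Measured in an ADME assay on HepG2 cells (Homo sapiens) for cytotoxicity, read by CellTiter-Glo and resazurin assay, with a stated time of 72 h; on this read-out lower numbers stand for an effect already at smaller amounts and higher numbers for an effect only at larger amounts of compound:
Compound 1 `CC(C)Oc1cccc(-c2ccc(C(=O)N(Cc3cccc(OCCCCCC(=O)O)c3)C(C)C)cc2)c1` gives > 26000 nM as a limit
Compound 2 `CC(C)N(Cc1cccc(OCCCCCC(=O)O)c1)C(=O)c1ccc(-c2ccc3c(c2)OCCO3)cc1` gives > 21900 nM as a limit
Compound 3 `COc1cc(OC)cc(-c2ccc(C(=O)N(Cc3cccc(OCCCCCC(=O)O)c3)C(C)C)cc2)c1` gives > 26000 nM as a limit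

Compound 3 stands only at the limit > 26000 nM and gives no number. Both the limit of > 21900 nM in this assay, at which 1 of the 3 values shown sits, and the limit of > 26000 nM in this assay, at which 2 of the 3 values shown sit, are limits, and no number stands among the three values. In compound 4 `CC(C)N(Cc1cccc(OCCCCCC(=O)O)c1)C(=O)c1ccc(-c2cccc(Br)c2)cc1` the change is 3-bromophenyl in place of 3,5-dimethoxyphenyl on an aromatic carbon on an aromatic carbon, para to a large group. Three measured steps exchange groups at this place: a step that the two limits leave unreadable from compound 1 to compound 2 and a step that the two limits leave unreadable from compound 1 to compound 3 and also a step that the two limits leave unreadable from compound 2 to compound 3 with no readable size in any of them. Among the compounds with values here, they therefore offer neither a direction nor a measure for the new change, and 3-bromophenyl itself has no measured precedent here. All they show is that these three groups each end at a limit. Resting on a step that the two limits leave unreadable from compound 1 to compound 3 and a step that the two limits leave unreadable from compound 2 to compound 3 with their unreadable sizes, the expected change is a number no higher from compound 3 to compound 4 (the limit leaves the size open) with no direction favoured and nothing expected beyond the scatter. Compound 4 is likewise expected to end at a limit in this assay rather than give a number. For compound 4 the estimate is 26000 nM with an expected range from 12000 nM to 50000 nM if a number is reported at all.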

Compound 4, half-maximal effective concentration: > 26000 nM
Compound 4: no number, only a limit; the forecaster's own chance of this, stated with the estimate: 80%; the middle value sits exactly at the limit.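

In this assay compound 4 gives > 26000 nM, which is a limit and not a number. Its steps from compound 1, compound 2 and compound 3 therefore cannot be read. The compounds shown leave open whether the groups exchanged at this place differ at all in this assay, and at what concentration any of the four compounds would show an effect.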